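A Dimethoxy Swap on a Weakly Cytotoxic Amide

The source may report more compounds than this note shows. Statements on the series, on what has been measured and on what is new or still open speak of the compounds shown alone.

For the measured compounds named here, compound 2 (`COc1cc2ncnc(Nc3ccc(F)c(Cl)c3)c2cc1NC(=O)/C=C/c1ccccc1[N+](=O)[O-]`) holds the only number in this small set. In a functional assay on MCF7 cells (Homo sapiens) for cytotoxicity, read by MTT assay, with a stated time of 72 h (a lower number here means a stronger inhibitor, a higher number a weaker inhibitor), compound 2 gives 36500 nM as its half-maximal inhibitory concentration. Compound 1 (`COc1ccc(/C=C/C(=O)Nc2cc3c(Nc4ccc(F)c(Cl)c4)ncnc3cc2OC)cc1`) has no number to set beside it: in this assay compound 1 is recorded as "not active" (no number reported) without a figure, so compound 2 cannot be ranked on a numerical scale.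

Compound 3 (`COc1ccc(/C=C/C(=O)Nc2cc3c(Nc4ccc(F)c(Cl)c4)ncnc3cc2OC)c(OC)c1`) differs from compound 2 in one place, with 2,4-dimethoxyphenyl in place of 2-nitrophenyl on a double-bonded chain carbon bound to a double-bonded chain carbon. Going by the values given here, no measured step between two compounds is available as a guide. The nearest hint is compound 1, which also carries a methoxy-bearing phenyl and is recorded as "not active" (no number reported) with no number, so no real gain is expected. The expected change is a 1.1-fold higher number from compound 2 to compound 3 (0.04 log units; within the scatter) and is not expected to exceed the scatter, in either direction. Compound 3 is estimated at 40000 nM with a range from 15000 nM to 100000 nM as its likely span, and it may equally be reported without a number.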

Compound 3, half-maximal inhibitory concentration: 36600 nM
Beside the measured number, compound 3's estimate is 1.1-fold (0.04 log units) above it; low and high end bracket the measured number.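

In this assay, replacing 2-nitrophenyl with 2,4-dimethoxyphenyl on a double-bonded chain carbon bound to a double-bonded chain carbon gives a 1.0-fold higher number from compound 2 to compound 3 (0.00 log units; within the scatter), so this first readable step at the position shows no separation between the two groups, even though one carries nitrogen and the other does not. The result also adds a second number to the series: compound 3 gives 36600 nM, whereas compound 1, which also carries a methoxy-bearing phenyl, stands as "not active" (no number reported), so a methoxy-bearing phenyl at this place does not always go without a figure. No independent evidence bears on this result.

The compounds shown leave open whether a phenyl bearing an amine or a carboxylic acid at this place, or a longer chain in place of the ethenyl link, would move the number beyond the scatter. They also leave open what separates the record of compound 1 from that of compound 3, since compound 1 has no figure that could be set against the number for compound 3.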